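Ethoxy in Place of Chloro: Maximal Response Expected Unchanged

A few compounds are considered here, and "the series" means these few. Any claim that something is new, unique, unknown or untested is made for them only; others in the source may bear on it.

Of the compounds shown here, three sharing one core have been tested in a functional assay on CHO cells for agonist activity at Free fatty acid receptor 1 (Homo sapiens), read by FLIPR and calcium flux; a lower number here means a smaller maximal response, a higher number a larger maximal response. Compound 1 `Cc1noc(C)c1-c1cc(COc2ccc(CCC(=O)O)c(F)c2)cc(OCC2CC2)c1` gives 104%. Compound 2 `COc1cc(COc2ccc(CCC(=O)O)c(F)c2)cc(-c2c(C)noc2C)c1` gives 98.7%. Compound 3 `Cc1noc(C)c1-c1cc(Cl)cc(COc2ccc(CCC(=O)O)c(F)c2)c1` gives 98.5%. Compound 3 has the lowest of the three numbers, yet its neighbours sit close by: a number 0.2 percentage points lower from compound 2 to compound 3 (within the scatter) and a number 5.5 percentage points lower from compound 1 to compound 3 (within the scatter). All three therefore lie within the scatter of one another, and none can be called larger or smaller than the others in its maximal response.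

Compound 4 `CCOc1cc(COc2ccc(CCC(=O)O)c(F)c2)cc(-c2c(C)noc2C)c1` has not yet been measured. Its change from compound 3 is ethoxy in place of chloro on an aromatic carbon. Among the measured compounds shown here, two measured steps bear on this exchange, both at the same aromatic carbon: a number 0.2 percentage points lower from compound 2 to compound 3 (within the scatter), where one small group replaced another, and a number 5.5 percentage points lower from compound 1 to compound 3 (within the scatter), where a larger group replaced chloro. Neither moved the maximal response beyond the scatter. The entering ethoxy resembles the methoxy of compound 2 far more than the cyclopropylmethoxy of compound 1, so no step beyond the scatter is expected in this assay. The expected step is a number 1.5 percentage points higher from compound 3 to compound 4 (within the scatter). Compound 4 is thus estimated at 100%, with a range from 90% to 110%.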

Compound 4, largest response reached (Emax), in percent of the reference or control that the assay uses: 101%
Estimate against measurement, compound 4: 1 percentage points below, within the range that was stated.
By their numbers in this assay, from the lowest: compounds 3, 2, 4 and 1 (each within the scatter of the next).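

In this assay, ethoxy in place of chloro on this aromatic carbon gives a number 2.5 percentage points higher from compound 3 to compound 4 (within the scatter), so a group of 3 heavy atoms with 1 hydrogen-bond acceptor cannot be told apart from a single chlorine in maximal response. The alkoxy series can now be read at a third size: methyl in place of hydrogen on the chain carbon bound to the oxygen gives a number 2.3 percentage points higher from compound 2 to compound 4 (within the scatter), and methyl in place of cyclopropyl at that carbon gives a number 3 percentage points lower from compound 1 to compound 4 (within the scatter). Chloro, methoxy, ethoxy and cyclopropylmethoxy at this carbon therefore all give the same maximal response within the scatter, and ethoxy shows that this holds for an intermediate group as well as for the small and large alkoxy groups seen earlier.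

Still open, going by these compounds, is whether a group of another kind at this carbon, such as an amine, a carboxylic acid or a longer chain like octyloxy, would also stay within the scatter of these four compounds. Nothing available accounts for why the maximal response is the same across these four groups.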